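The compounds below may be only part of what the source reports. "The series", "measured", "known", "first", "only" and "open" are said of these compounds alone.

Three compounds have been measured in an assay on H4 cells for inhibition of Fatty-acid amide hydrolase 1 (Homo sapiens); a lower number here means a stronger inhibitor, a higher number a weaker inhibitor:

compound 1 `CCCCOc1ccc(C(CC)NC(=O)Oc2ccccc2F)cc1` gives 7.7 nM
compound 2 `CCCCOc1ccc(CNC(=O)Oc2cccc(Cl)c2)cc1` gives 12 nM
compound 3 `CCCCOc1ccc(CNC(=O)Oc2ccc(F)cc2F)cc1` gives 8.7 nM

On these numbers compound 3 sits among the others rather than apart from them: compared with compound 1 its value differs only within the usual scatter, and the step of a 1.4-fold lower number from compound 2 to compound 3 (0.14 log units; within the scatter) is likewise within the scatter. None of the three values can be told apart with confidence.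

Compound 4 `CCCCOc1ccc(CNC(=O)Oc2ccccc2F)cc1` differs from compound 3 by hydrogen in place of fluoro on an aromatic carbon. Among the measured compounds shown here, only one measured step bears on changes at the aryl ester of this series, a 1.4-fold lower number from compound 2 to compound 3 (0.14 log units; within the scatter), and it was small. The carbamate aryl group has so far tolerated a fluoro or chloro in different positions without a shift beyond the scatter, so removing one fluoro is expected to leave the number close to that of compound 3. The step of a 1.0-fold higher number from compound 3 to compound 4 (0.01 log units; within the scatter) is therefore expected to be negligible. For compound 4 the estimate is 9 nM, in the range 4 nM to 20 nM.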

Compound 4, half-maximal inhibitory concentration: 9.2 nM
For compound 4 the middle estimate is 1.0-fold (0.01 log units) below the measured one, and the stated range covers the measured number.
By their numbers in this assay, from the lowest: compounds 1, 3, 4 and 2 (each within the scatter of the next).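

In this assay, the change from 2,4-difluorophenyl to 2-fluorophenyl gives a 1.1-fold higher number from compound 3 to compound 4 (0.02 log units; within the scatter), so at this aromatic carbon, para to a large group, hydrogen and fluoro cannot be told apart. The other two comparisons read the same way: 2-fluorophenyl in place of 3-chlorophenyl gives a 1.3-fold lower number from compound 2 to compound 4 (0.12 log units; within the scatter), and hydrogen in place of ethyl on the saturated chain carbon gives a 1.2-fold higher number from compound 1 to compound 4 (0.08 log units; within the scatter), so none of the three changes shifts the number beyond the scatter. No measurement is at hand to explain this flat picture.

Going by these compounds, what a nitrile or a methoxy group would do at this aromatic carbon remains open. So does the outcome of placing an amine or a carboxylic acid on the aromatic ring of the carbamate oxygen.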